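This account rests on a few compounds, and the source may have more. Where it says the series, first, only, none or still open, it means among the compounds named here.

Three compounds built on one shared core have been examined in a physicochemical assay for solubility; on this read-out higher numbers stand for higher solubility and lower numbers for lower solubility. Compound 1 `COc1ccccc1C(=O)NC(=O)Nc1ccc(-c2ccccc2)c(C(F)(F)F)c1` reaches in this assay only a limit, < 1 ug/mL, which is a boundary of the assay rather than a number. Compound 2 `COc1ccccc1C(=O)NC(=O)Nc1ccc(-c2nccs2)c(C(F)(F)F)c1` gives 1.1 ug/mL in this assay. Compound 3 `COc1ccccc1C(=O)NC(=O)Nc1ccc(N2CCCCC2)c(C(F)(F)F)c1` gives 3 ug/mL in this assay, the highest of the two plain numbers shown; the rise from compound 2 is a 2.7-fold higher number from compound 2 to compound 3 (0.44 log units; beyond the scatter). Seen from the limit of compound 1, the change is an at least 3.0-fold higher number from compound 1 to compound 3 (0.47 log units; beyond the scatter).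

Compound 4 `COc1ccccc1C(=O)NC(=O)Nc1ccc(-c2ccccn2)c(C(F)(F)F)c1` has not yet been measured. It differs from compound 3 in one place: pyridin-2-yl in place of piperidin-1-yl on an aromatic carbon. The most relevant measured step is a 2.7-fold higher number from compound 2 to compound 3 (0.44 log units; beyond the scatter), in which an aromatic ring with one hetero atom was exchanged for piperidin-1-yl; the change to compound 4 runs the other way, from piperidin-1-yl back to an aromatic ring with one hetero atom. The step of an at least 1.1-fold higher number from compound 1 to compound 2 (0.04 log units; that floor lies within the scatter) shows that two different aromatic rings at this position gave close results. A downward step of about a 2.5-fold lower number from compound 3 to compound 4 (0.40 log units; beyond the scatter) is therefore expected in this assay. Compound 4 is expected to give roughly 1.2 ug/mL, most likely between 0.5 ug/mL and 3 ug/mL.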

Compound 4, solubility: 28 ug/mL
Compound 4: middle estimate off by 23-fold (1.37 log units), on the low side, outside the stated range (above it).
By their numbers in this assay, from the lowest: compound 2; then compound 3; then compound 4. At a limit, below all of these: compound 1.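

At this position, on an aromatic carbon para to a large group and ortho to a trifluoromethyl group, aromatic rings are clearly not interchangeable: in this assay, pyridin-2-yl in place of 1,3-thiazol-2-yl gives a 25-fold higher number from compound 2 to compound 4 (1.41 log units; beyond the scatter) and leaves the earlier closeness of aromatic rings behind. Piperidin-1-yl and pyridin-2-yl have the same counts of heavy atoms, hydrogen-bond donors and acceptors, yet the exchange gives a 9.3-fold higher number from compound 3 to compound 4 (0.97 log units; beyond the scatter), while a non-aromatic ring does not simply rank below or above an aromatic one, since the piperidin-1-yl compound falls between the 1,3-thiazol-2-yl compound and the pyridin-2-yl compound. The phenyl compound's reading is a limit, so the change from phenyl to pyridin-2-yl reads as an at least 28-fold higher number from compound 1 to compound 4 (1.44 log units; beyond the scatter) and stands on that limit: the limit of < 1 ug/mL in this assay, at which 1 of the 4 values shown sits.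

The compounds shown do not explain the high value of the pyridin-2-yl compound, and they cannot tell whether it depends on where the nitrogen sits in the ring, which pyridin-3-yl and pyridin-4-yl would address. Also open, on these data alone, is how a morpholin-4-yl ring or a simple dimethylamino group would compare at this position.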